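Anilide series: methoxy to hydroxy on the benzamide ring

The source may report more compounds than this note shows. Statements on the series, on what has been measured and on what is new or still open speak of the compounds shown alone.

Measured so far:
Compound 1 `O=C(Nc1ccccc1)c1cccc(Br)c1`: > 100000 nM
Compound 2 `COc1ccccc1C(=O)Nc1ccc(Sc2nc3ccccc3s2)cc1`: > 100000 nM
Compound 3 `COc1ccccc1C(=O)Nc1cccc(Cl)c1`: > 100000 nM

In an assay for inhibition of HSP60/HSP10 (Homo sapiens), with a stated time of 60 min (a lower number here means a stronger inhibitor, a higher number a weaker inhibitor), compound 2 gives > 100000 nM, which is a limit of the assay and not a number. Compound 1 likewise gives only a limit, > 100000 nM. Compound 3 also reaches only a limit, > 100000 nM. Within the data shown here, all three values sit at the limit of > 100000 nM in this assay, at which 3 of the 3 values shown sit, so no step between measured compounds can be computed, and nothing so far separates one compound from another.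

The next compound, compound 4 `O=C(Nc1ccc(Sc2nc3ccccc3s2)cc1)c1ccccc1O`, differs from compound 2 in one place: hydrogen in place of methyl on an oxygen on an aromatic ring. Read one bond further out, this is methoxy to hydroxy on the benzamide ring, hydrogen in place of methyl on an oxygen on an aromatic ring.

Among the measured compounds shown here, with compound 2 at a limit and no measured step to lean on, compound 4 is expected to stay near that limit, with an estimate of 100000 nM and a range from 30000 nM to 300000 nM. The step of a number no higher from compound 2 to compound 4 (the limit leaves the size open) is expected to be none beyond the usual scatter.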

Compound 4, half-maximal inhibitory concentration: > 100000 nM
Compound 4 ended at the assay's limit; the forecaster's own chance of this, stated with the estimate: 80%; the middle value sits exactly at the limit.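

In this assay compound 4 gives > 100000 nM, which is a limit of the assay and not a number. With compound 2 also at a limit, no step can be read between compound 2 and compound 4. The compounds shown leave open whether methoxy to hydroxy changes binding in this assay at all.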